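A few compounds are considered here, and "the series" means these few. Any claim that something is new, unique, unknown or untested is made for them only; others in the source may bear on it.

Among the compounds with values here, compound 1, with the structure `CNC(=O)c1nnc2ccc(-c3ccc(COC)nc3)cc2c1N[C@@H](C)C1CCOCC1`, is the weakest of the three compounds measured so far. In an assay on HT-29 cells for inhibition of Serine-protein kinase ATM (Homo sapiens), read by fluorescence, with a stated time of 1 h (on this read-out lower numbers stand for stronger inhibition and higher numbers for weaker inhibition), compound 1 gives 330 nM, the highest of the three numbers. The nearest is compound 3, `C[C@H](Nc1c(C(N)=O)nnc2ccc(-c3ccc(NCCN(C)C)nc3)cc12)C1CCOCC1`, which in this assay gives 61 nM, a step beyond the scatter; furthest away is compound 2, `C[C@H](Nc1c(C(N)=O)nnc2ccc(-c3ccc(OCCCN4CCCC4)nc3)cc12)c1ccn(C)n1`, which gives 1.1 nM, also well beyond the scatter. Both compound 2 and compound 3 differ from compound 1 in more than one place, so their values show only that other substitution patterns on the shared core reach much lower numbers, not which part of the change matters.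

The next compound, compound 4, has the structure `CNC(=O)c1nnc2ccc(-c3ccc(OCCCN(C)C)nc3)cc2c1N[C@@H](C)C1CCOCC1`. It differs from compound 1 in a single place: 3-(dimethylamino)propoxy in place of methoxymethyl on an aromatic carbon. Within the data shown here, no measured pair isolates this particular change, so its effect has to be guessed from the rough direction set by compound 2 and compound 3, both of which carry longer chains in the same region and both of which sit far below compound 1.

On that basis the step from compound 1 to compound 4 is expected to lower the number, estimated as an 8.3-fold lower number from compound 1 to compound 4 (0.92 log units; beyond the scatter). Compound 4 is therefore estimated at 40 nM in this assay, within a range of 10 nM to 160 nM.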

Compound 4, half-maximal inhibitory concentration in the Serine-protein kinase ATM assay: 2.8 nM
Estimate against measurement, compound 4: 14-fold (1.15 log units) above, outside the stated range (below it).
By their numbers in the Serine-protein kinase ATM assay, from the lowest: compound 2; then compound 4; then compound 3; then compound 1.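

In the Serine-protein kinase ATM assay, placing 3-(dimethylamino)propoxy instead of methoxymethyl on this aromatic carbon, next to the ring nitrogen, gives a 120-fold lower number from compound 1 to compound 4 (2.07 log units; beyond the scatter). Within the data shown here, the rest of the molecule stays the same, so this group alone moves the number by a large step, something the earlier compounds could not show, as they differ from compound 1 in more than one place. In a physicochemical assay for lipophilicity, using the shake flask method, measured as octanol-water partition, with a stated time of 30 min, at pH 7.4 (a lower number here means a more polar compound, a higher number a more lipophilic compound), compound 1 gives 3, and compound 4 gives 2.3. The stronger inhibition also comes with a less lipophilic compound in the physicochemical assay: the measured distribution coefficient of compound 1, 3, and of compound 4, 2.3, a number 0.70 log units lower (beyond the scatter)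

The compounds shown do not separate the contributions of the terminal dimethylamino group, the ether oxygen and the length of the chain, so it remains open which of these parts matters. A plain propoxy group with no amine, or a morpholine at the end of the same chain, would help to answer this, since each changes the chain end while keeping its length.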